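The source may hold more compounds than are shown below. What is called first, only, known or untested is meant among the compounds shown, and "the series" means these compounds.

Measured compounds in this series:

compound 1, `Cc1cc(C)c2c(c1)CN(c1ccc3c(=O)cc(-c4ccccc4)oc3c1)CO2`, gives 11.3% in a functional assay on MCF7 cells (Homo sapiens) for inhibition, read by MTT assay, with a stated time of 48 h, tested at 7.5 ug/mL; a higher number here means more inhibition of growth at the concentration tested, a lower number less inhibition of growth
compound 2, `O=c1cc(-c2ccccc2)oc2ccc(N3COc4ccccc4C3)cc12`, gives 8.7% in this assay
compound 3, `Cc1cccc2c1OCN(c1ccc3c(=O)cc(-c4ccccc4)oc3c1)C2`, gives 43.9% in this assay

Compound 3 and compound 1 differ in one place, the change being (methyl in place of hydrogen on an aromatic carbon), and this step is large and beyond the scatter: a number 32.6 percentage points lower from compound 3 to compound 1 (beyond the scatter). Compound 2 and compound 1 differ only within the scatter, so nothing is said here about an order between them. The difference between the core of compound 2 and the core of compound 3 is not broken down here.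

Compound 4, `Cc1ccc2c(c1)CN(c1ccc3oc(-c4ccccc4)cc(=O)c3c1)CO2`, has not yet been measured. It differs from compound 2 by methyl in place of hydrogen on an aromatic carbon. Among the compounds with values here, this is the same kind of change as the one from compound 3 to compound 1, though the surroundings differ: in the step from compound 3 to compound 1 the entering methyl also sits meta to a methyl group, which is not so in compound 4.

Within the data shown here, for this assay the earlier step is the only guide, and it ran strongly downward. Compound 2, however, already gives 8.7%, leaving little room for a further fall of that size, and compound 1, which carries the same change on a different background, gives 11.3%. Compound 4 is therefore expected to show only a small step, estimated as a number 3.3 percentage points higher from compound 2 to compound 4 (within the scatter). The estimate for compound 4 is 12%, with a range from 2% to 28%.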

Compound 4, percent growth inhibition at one concentration: 16.5%
Beside the measured number, compound 4's estimate is 4.5 percentage points below it, within the range that was stated.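

In this assay, methyl in place of hydrogen on an aromatic carbon gives a number 7.8 percentage points higher from compound 2 to compound 4 (within the scatter), so on this core the change has no effect that can be told apart from the scatter. Set beside the earlier step, the same change does not carry over from one core to the other with the same outcome: the same change on two cores in this assay, a number 32.6 percentage points lower (beyond the scatter) from compound 3 to compound 1 and a number 7.8 percentage points higher (within the scatter) from compound 2 to compound 4, 40.4 percentage points apart, beyond the scatter of two such steps This shows that, in this series, the step seen on one core cannot simply be transferred to another, but it does not show what sets the two steps apart, since the two pairs differ both in the core and in the surroundings of the entering methyl, and two pairs give no rule for any further core.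

From the compounds shown here alone, only hydrogen and methyl appear on the aromatic carbons that change here, so the outcome with a halogen such as chlorine, a methoxy group or an amine in these places remains open. Also open, going by these compounds, is whether the gap between the two steps would persist in a read-out across several concentrations or in cell lines other than the one used here.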